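The source may report more compounds than this note shows. Statements on the series, on what has been measured and on what is new or still open speak of the compounds shown alone.

Compound 1 `CC(C)S(=O)(=O)c1ccc(Cl)c(C#Cc2cc(Cl)ccc2OCC(=O)O)c1` is the starting point. Within the data shown here, in an assay on CHO cells for displacement of a labelled ligand from prostaglandin D2 receptor 2 (Homo sapiens), read by scintillation counting (on this read-out lower numbers stand for stronger inhibition and higher numbers for weaker inhibition), compound 1 gives 2.9 nM, the lowest of the two numbers measured so far; the only companion, compound 2 `CC1(C)C(=O)c2ccc(C#Cc3cc(Cl)ccc3OCC(=O)O)cc2S1(=O)=O`, gives 31 nM in this assay, a difference that lies beyond the usual scatter. Compound 3 `O=C(O)COc1ccc(Cl)cc1C#Cc1ccccc1Cl` has not yet been measured; it differs from compound 1 in one place, (hydrogen in place of isopropylsulfonyl on an aromatic carbon), so a large group is simply taken away and nothing stands in its stead. Among the measured compounds shown here, no measured pair shows this exact change, so the expectation rests on the structures alone. Removing a group of that size from the core of compound 1 is expected to weaken binding in this assay by a clear margin, beyond the scatter. For compound 3 the estimated result is 80 nM, with a likely range from 15 nM to 500 nM, corresponding to an expected step of a 28-fold higher number from compound 1 to compound 3 (1.44 log units; beyond the scatter).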

Compound 3, inhibition constant: 28 nM
Compound 3: middle estimate off by 2.9-fold (0.46 log units), on the high side, within the range that was stated.
By their numbers in this assay, from the lowest: compound 1; then compounds 3 and 2 (each within the scatter of the next).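

In this assay, putting hydrogen in place of isopropylsulfonyl on this aromatic carbon gives a 9.7-fold higher number from compound 1 to compound 3 (0.98 log units; beyond the scatter), a modest step but one beyond the usual scatter, so the group does contribute to the stronger number of compound 1. The group is not indispensable, however: even without it, compound 3 gives 28 nM, so much of the binding remains when these six heavy atoms are gone. Nothing measured here explains why removing the group has this effect.

Only two substituents are shown on this carbon, isopropylsulfonyl and hydrogen, so the compounds do not reveal which part of the group matters. A plain isopropyl group, a smaller methylsulfonyl group or an amine at the same place could each help to separate the contribution of the sulfonyl from that of its carbon chain.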